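The compounds below may be only part of what the source reports. "The series", "measured", "known", "first", "only" and "open" are said of these compounds alone.

Measured so far in a functional assay on Huh-7 cells (Homo sapiens) for inhibition, read by sulforhodamine B assay; on this read-out higher numbers stand for weaker inhibition and lower numbers for stronger inhibition:

compound 1 `C#CC(=O)N1C(CCCC)SC[C@@H]1C(=O)OCC`: 500 nM
compound 2 `C#CC(=O)N1C(c2ccccc2)SC[C@@H]1C(=O)OCC`: 5300 nM
compound 3 `C#CC(=O)N1C(c2ccccc2F)SC[C@@H]1C(=O)OCC`: 1700 nM

Among these three numbers compound 3 stands second highest: compound 2 lies above it, and the step between them, a 3.1-fold lower number from compound 2 to compound 3 (0.49 log units; beyond the scatter), is beyond the scatter, while compound 1 lies below it, with the step of a 3.4-fold higher number from compound 1 to compound 3 (0.53 log units; beyond the scatter) also beyond the scatter. Compound 4 `C#CC(=O)N1C(C(C)(C)C)SC[C@@H]1C(=O)OCC` differs from compound 3 in one place: tert-butyl in place of 2-fluorophenyl on a saturated ring carbon.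

Going by the values given here, the measured step that bears on this change is the one from compound 1 to compound 3, a 3.4-fold higher number from compound 1 to compound 3 (0.53 log units; beyond the scatter), where butyl gave way to 2-fluorophenyl and the number rose modestly. The change to compound 4 runs the other way, back from 2-fluorophenyl to a carbon-only group without a ring. Among the compounds with values here, no measured compound carries tert-butyl, so how a branched group compares with butyl is unknown here. A modestly lower number than that of compound 3 is therefore expected, though with wide uncertainty. For compound 4 the estimate is 700 nM, with a range from 250 nM to 2000 nM, a step of a 2.4-fold lower number from compound 3 to compound 4 (0.39 log units; beyond the scatter) expected.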

Compound 4, half-maximal inhibitory concentration: 800 nM
The estimate for compound 4 lay 1.1-fold (0.06 log units) below the measured number; measured number inside the range.
By their numbers in this assay, from the lowest: compounds 1 and 4 (each within the scatter of the next); then compound 3; then compound 2.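

In this assay, tert-butyl brings a 2.1-fold lower number from compound 3 to compound 4 (0.33 log units; beyond the scatter) when it replaces 2-fluorophenyl and a 6.6-fold lower number from compound 2 to compound 4 (0.82 log units; beyond the scatter) when it replaces phenyl, so both groups with an aromatic ring give higher numbers than this carbon-only group without a ring. Against butyl it gives a 1.6-fold higher number from compound 1 to compound 4 (0.20 log units; within the scatter), so for this pair, branching the four-carbon group at this saturated ring carbon makes no difference that this assay can distinguish. Nothing available explains why the aromatic groups give the higher numbers.

A cyclohexyl group would help to show whether the higher numbers go with any ring or only with an aromatic one. From the compounds shown here alone, it also remains open how a group as small as methyl, or a longer chain such as octyl, would compare with butyl and tert-butyl.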